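The source may report more compounds than this note shows. Statements on the series, on what has been measured and on what is new or still open speak of the compounds shown alone.

Measured compounds:
compound 1 `O=C1c2c[n+]([O-])c3ccccc3c2C(=O)c2c1c1ccccc1n2Cc1cn(C[C@H](O)CO)nn1`, 1130 nM in a toxicity assay on L02 cells (Homo sapiens) for cytotoxicity, read by MTT assay, with a stated time of 72 h; a higher number here means a weaker inhibitor, a lower number a stronger inhibitor
compound 2 `CC1(C)OC[C@H](Cn2cc(Cn3c4c(c5ccccc53)C(=O)c3c[n+]([O-])c5ccccc5c3C4=O)nn2)O1`, 470 nM in this assay

Compound 1 stands at the higher of the two numbers; the step to compound 2 is a 2.4-fold lower number from compound 1 to compound 2 (0.38 log units; beyond the scatter). Compound 3 `O=C1c2c[n+]([O-])c3ccccc3c2C(=O)c2[nH]c3ccccc3c21` differs from compound 1 by hydrogen in place of (1-(2,3-dihydroxypropyl)-1H-1,2,3-triazol-4-yl)methyl on an aromatic nitrogen. For the measured compounds named here, the only measured step swaps a group at the end of that chain while the chain stays in place, so it gives no guide to removing the chain entirely; no measured step does. The expectation for compound 3 is therefore a step of a 1.0-fold lower number from compound 1 to compound 3 (0.01 log units; within the scatter), with no confident direction and a wide range. Compound 3 is estimated at 1100 nM, between 250 nM and 5000 nM.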

Compound 3, half-maximal inhibitory concentration: 400 nM
The estimate for compound 3 lay 2.8-fold (0.44 log units) above the measured number; low and high end bracket the measured number.
By their numbers in this assay, from the lowest: compounds 3 and 2 (each within the scatter of the next); then compound 1.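

For the compounds shown here, replacing the (1-(2,3-dihydroxypropyl)-1H-1,2,3-triazol-4-yl)methyl on the aromatic nitrogen with hydrogen gives a 2.8-fold lower number from compound 1 to compound 3 (0.45 log units; beyond the scatter) in this assay, the first step to remove the whole chain rather than alter its end. The shared core with only hydrogen at this position therefore still acts on these cells, and adding the chain to it in compound 1 gives a higher number, meaning weaker toxicity. Nothing available explains this change. As far as these compounds go, whether a small methyl or a chain ending in an amine on this nitrogen would give a lower or higher number remains open.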